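This account rests on a few compounds, and the source may have more. Where it says the series, first, only, none or still open, it means among the compounds named here.

Compound 1 `COc1cc2c(Oc3ccc(NC(=O)c4nn(-c5ccccc5F)c(=O)c5ccccc45)cc3F)ccnc2cc1OCCCN1CCCC1` gives 950 nM in a functional assay on MDA-MB-231 cells (Homo sapiens) for cytotoxicity, read by MTT assay, with a stated time of 72 h; a higher number here means a weaker inhibitor, a lower number a stronger inhibitor. Compound 2 `COc1cc2c(Oc3ccc(NC(=O)c4nn(-c5ccc(Br)cc5)c(=O)c5ccccc45)cc3F)ccnc2cc1OCCCN1CCCC1` carries 4-bromophenyl in place of 2-fluorophenyl on an aromatic nitrogen, and in this assay compound 2 gives 1160 nM; the step reads a 1.2-fold higher number from compound 1 to compound 2 (0.09 log units; within the scatter). Compound 3 `COc1cc2c(Oc3ccc(NC(=O)c4nn(-c5ccccc5F)c(=O)c5ccccc45)cc3F)ccnc2cc1OCCCN1CCCCC1` differs from compound 1 in the core by piperidin-1-yl in place of pyrrolidin-1-yl on a saturated chain carbon, three bonds along the chain from an oxygen on an aromatic ring, and in this assay compound 3 gives 910 nM, a step of a 1.0-fold lower number from compound 1 to compound 3 (0.02 log units; within the scatter). All three measured values lie within the scatter of one another, so none of the three can be set apart from the others on this evidence.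

Compound 4 `COc1cc2c(Oc3ccc(NC(=O)c4nn(-c5ccc(Br)cc5)c(=O)c5ccccc45)cc3F)ccnc2cc1OCCCN1CCCCC1` has not yet been measured in this assay. It differs from compound 3 by 4-bromophenyl in place of 2-fluorophenyl on an aromatic nitrogen. This is the same change that separates compound 1 from compound 2, now made on the core of compound 3 rather than on the core of compound 1; the surroundings of the place are described in the same words for both pairs, so it counts as the same change, occurring twice among the compounds shown. The earlier instance produced a 1.2-fold higher number from compound 1 to compound 2 (0.09 log units; within the scatter). Since the two cores themselves give numbers within the scatter of each other, the expectation is that the change will behave much as before, and a step of a 1.2-fold higher number from compound 3 to compound 4 (0.09 log units; within the scatter) in this assay is expected, resting on the earlier step of a 1.2-fold higher number from compound 1 to compound 2 (0.09 log units; within the scatter). Compound 4 is therefore estimated at 1110 nM in this assay, with a range from 700 nM to 1800 nM.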

Compound 4, half-maximal inhibitory concentration: 1130 nM
Beside the measured number, compound 4's estimate is 1.0-fold (0.01 log units) below it; the range from low to high includes it.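

In this assay, 4-bromophenyl in place of 2-fluorophenyl gives a 1.2-fold higher number from compound 3 to compound 4 (0.09 log units; within the scatter), and the change carries from the core of compound 1 to the core of compound 3 with no difference that can be read: the same change on two cores in this assay, a 1.2-fold higher number (0.09 log units; within the scatter) from compound 1 to compound 2 and a 1.2-fold higher number (0.09 log units; within the scatter) from compound 3 to compound 4, 1.0-fold (0.01 log units) apart, within the scatter of two such steps. The other change, piperidin-1-yl in place of pyrrolidin-1-yl, gives a 1.0-fold lower number from compound 2 to compound 4 (0.01 log units; within the scatter) and likewise agrees with its earlier instance: the same change on two cores in this assay, a 1.0-fold lower number (0.02 log units; within the scatter) from compound 1 to compound 3 and a 1.0-fold lower number (0.01 log units; within the scatter) from compound 2 to compound 4, 1.0-fold (0.01 log units) apart, within the scatter of two such steps. This shows that, across these four compounds, each change leaves the number within the scatter on both cores, but it does not show that a real effect of either change transfers from one core to the other, since steps this small give no measurable effect to compare and their agreement is a weak test.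

The compounds shown leave open whether any group on the aromatic nitrogen other than these two, such as a methyl or an unsubstituted phenyl, would give a step beyond the scatter. They also leave open whether a morpholin-4-yl or a dimethylamino group at the end of the chain, or a shorter or longer chain, would do so, and whether such a step would then carry from one core to another.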